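Methylsulfanyl for Methyl, Tried Again on Another Core

The compounds below may be only part of what the source reports. "The series", "measured", "known", "first", "only" and "open" are said of these compounds alone.

In a functional assay on HEK293 cells for antagonist activity at transient receptor potential cation channel subfamily V member 1 (Homo sapiens), read by calcium flux (a higher number here means a weaker inhibitor, a lower number a stronger inhibitor), three compounds have been measured:

Compound 1 `Cc1ccc(Nc2ncnc3sc(Nc4c(Cl)cccc4Cl)nc23)cc1` gives 33 nM.
Compound 2 `CSc1ccc(Nc2ncnc3sc(Nc4c(Cl)cccc4Cl)nc23)cc1` gives 96 nM.
Compound 3 `Cc1nc(Nc2ccc(C(F)(F)F)c(Cl)c2)c2nc(Nc3c(Cl)cccc3Cl)sc2n1` gives 3 nM.

Compound 1 and compound 2 share a core and differ in one place: methylsulfanyl in place of methyl on an aromatic carbon. That change gave a 2.9-fold higher number from compound 1 to compound 2 (0.46 log units; beyond the scatter). Compound 3 sits on a different core; how the two cores differ is not broken down here. Its value is the lowest of the three, and its steps to both others lie beyond the scatter.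

Compound 4 `CSc1nc(Nc2ccc(C(F)(F)F)c(Cl)c2)c2nc(Nc3c(Cl)cccc3Cl)sc2n1` is not yet measured. It is derived from compound 3 by methylsulfanyl in place of methyl on an aromatic carbon. The place is not the same as in the first pair, where the change sat on a six-membered aromatic ring of carbon only, para to a large group; here it sits on a six-membered aromatic ring with 2 nitrogen, part of a fused system, between two ring nitrogen atoms. It is the same kind of change, not the same change.

Among the measured compounds shown here, the expectation for compound 4 is a step of a 3.0-fold higher number from compound 3 to compound 4 (0.48 log units; beyond the scatter), because a 2.9-fold higher number from compound 1 to compound 2 (0.46 log units; beyond the scatter) is the only measured instance of this change and the size of that step is what the expectation rests on. Compound 4 is thus estimated at 9 nM, with a range from 3 nM to 27 nM.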

Compound 4, half-maximal inhibitory concentration: 224 nM
Compound 4: the middle estimate sits 25-fold (1.40 log units) below what was measured; the whole stated range lies below it.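

In this assay, methylsulfanyl in place of methyl gave a much larger step on the core of compound 3, a 75-fold higher number from compound 3 to compound 4 (1.87 log units; beyond the scatter), and the two instances of the change do not agree in size: the same change on two cores in this assay, a 2.9-fold higher number (0.46 log units; beyond the scatter) from compound 1 to compound 2 and a 75-fold higher number (1.87 log units; beyond the scatter) from compound 3 to compound 4, 26-fold (1.41 log units) apart, beyond the scatter of two such steps. The number rose in both pairs, so the direction held across these two cores, but the size of the step on one core did not carry over to the other. Among the compounds shown here, with only two pairs, and the change sitting at a different place in each, the data cannot separate the effect of the core from that of the place, and they offer no rule for a third core.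

The compounds shown leave open how other groups would read at the place between two ring nitrogen atoms on the core of compound 3, for instance a methoxy group, an amine or an ethyl chain. They also leave open whether the large step is particular to methylsulfanyl or would appear with such groups as well.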